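The source may report more compounds than this note shows. Statements on the series, on what has been measured and on what is new or still open speak of the compounds shown alone.

The series rests on a shared core, shown in compound 1 `CC(=O)OCc1ccc2oc(=O)c(C(=O)Oc3cccc(Br)c3)cc2c1`, compound 2 `CC(=O)OCc1ccc2oc(=O)c(C(=O)Sc3cccc(Br)c3)cc2c1` and compound 3 `CCC(=O)OCc1ccc2oc(=O)c(C(=O)Oc3cccc(Br)c3)cc2c1`. In a functional assay on HT-1080 cells (Homo sapiens), read by transwell migration, with a stated time of 24 h, tested at 10 uM (on this read-out higher numbers stand for a weaker effect at the one concentration tested and lower numbers for a stronger effect), compound 1 gives 11.8%, compound 2 gives 67.8% and compound 3 gives 21.3%. Compound 3 thus stands second highest of the three numbers, with compound 1 nearest, a number 9.5 percentage points higher from compound 1 to compound 3 (within the scatter), and compound 2 furthest, a number 56 percentage points higher from compound 1 to compound 2 (beyond the scatter) away from compound 1.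

Compound 4 `CCCC(=O)OCc1ccc2oc(=O)c(C(=O)Oc3cccc(Br)c3)cc2c1` has not yet been measured. It differs from compound 3 by methyl in place of hydrogen on a saturated chain carbon, two bonds along the chain from a carbonyl carbon. Within the data shown here, the one measured step that bears on this change is the lengthening of the same chain from compound 1 to compound 3, a number 9.5 percentage points higher from compound 1 to compound 3 (within the scatter). That step stayed within the scatter, so the account expects the further lengthening in this assay to give no change beyond the scatter, a step estimated at a number 3.7 percentage points higher from compound 3 to compound 4 (within the scatter). The value for compound 4 is therefore estimated at 25%, within a range from 10% to 42%.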

Compound 4, a percentage reported as activity, at one concentration (the size of the read-out at that concentration, not a potency): 24.7%
The estimate for compound 4 lay 0.3 percentage points above the measured number; the range from low to high includes it.
By their numbers in this assay, from the lowest: compounds 1, 3 and 4 (each within the scatter of the next, the first and the last beyond it); then compound 2.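

In this assay the added methyl on its own gives a step that cannot be told from the scatter, a number 3.4 percentage points higher from compound 3 to compound 4 (within the scatter), just as the previous lengthening of the same chain could not. Read over the whole change, however, the two lengthenings taken together give a number 12.9 percentage points higher from compound 1 to compound 4 (beyond the scatter), so this position does respond to chain length, modestly, in a way that neither single step could show. Nothing given here accounts for this step.

Going by these compounds, it remains open whether a longer chain, a branched chain or a chain ending in an amine would carry the difference further. On these data alone, it is also open whether the same lengthening would read alike with (3-bromophenyl)sulfanyl in place of 3-bromophenoxy.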